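Piperidine substituents on the shared core

The source may report more compounds than this note shows. Statements on the series, on what has been measured and on what is new or still open speak of the compounds shown alone.

Measured so far in an assay for inhibition of serine/threonine-protein kinase 4 (Homo sapiens), read by luminescence and ADP-Glo, in the presence of a further agent that is not named here; on this read-out higher numbers stand for weaker inhibition and lower numbers for stronger inhibition:
Compound 1 `CCCN(C)c1ncnc2[nH]cc(-c3cccc(Cl)c3)c12` gives 208 nM.
Compound 2 `CC(=O)NC1CCN(c2ncnc3[nH]cc(-c4cccc(Cl)c4)c23)CC1` gives 26 nM.
Compound 3 `CC1(O)CCN(c2ncnc3[nH]cc(-c4cccc(Cl)c4)c23)CC1` gives 145 nM.

Compound 3 stands second highest of the three numbers. Its nearest neighbour is compound 1, and the step of a 1.4-fold lower number from compound 1 to compound 3 (0.16 log units; within the scatter) lies within the scatter. Going by the values given here, compound 2 gives the lowest number of the three, and the gap between compound 2 and compound 3 is beyond the scatter; no single-site step between these two is given.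

Compound 4 `Clc1cccc(-c2c[nH]c3ncnc(N4CCCCC4)c23)c1` differs from compound 3 as follows: piperidin-1-yl in place of 4-hydroxy-4-methylpiperidin-1-yl on an aromatic carbon. The change removes the hydroxy and the methyl from the piperidine ring while keeping the ring attachment to the shared core. Among the compounds with values here, no measured step bears directly on this change. Within the data shown here, the only measured step, from compound 1 to compound 3, exchanges an open-chain amine for the substituted ring and is within the scatter, so it gives no direction for stripping substituents from the ring. The values of compound 2 and compound 3 show that what sits on the piperidine ring can move the number beyond the scatter, but where the bare ring falls is not told by these data.

A modest step, if any, is expected in this assay for compound 4, with the number estimated as 250 nM (range 100 nM to 650 nM). This corresponds to an expected step of a 1.7-fold higher number from compound 3 to compound 4 (0.24 log units; within the scatter).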

Compound 4, half-maximal inhibitory concentration: 48 nM
Compound 4: middle estimate off by 5.2-fold (0.72 log units), on the high side; the measured number lies below the stated range.
By their numbers in this assay, from the lowest: compounds 2 and 4 (each within the scatter of the next); then compounds 3 and 1 (each within the scatter of the next).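

In this assay, the substituents on the piperidine ring do not behave as a single trend: the bare piperidin-1-yl of compound 4 gives a lower number than the 4-hydroxy-4-methylpiperidin-1-yl ring (a 3.0-fold lower number from compound 3 to compound 4 (0.48 log units; beyond the scatter)), so carrying the hydroxy and methyl together costs on this read-out. The acetamido group of compound 2 is not shown to add anything over the bare ring (a 1.8-fold higher number from compound 2 to compound 4 (0.27 log units; within the scatter)), so the earlier gap between compound 2 and compound 3 now reads as a rise in compound 3 and not as a gain in compound 2. The ring also now separates from the open chain (a 4.3-fold lower number from compound 1 to compound 4 (0.64 log units; beyond the scatter)), which the step from compound 1 to compound 3 could not show, as that step stayed within the scatter.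

No measurement on hand accounts for these steps.

From the compounds shown here alone, compound 3 carries the hydroxy and the methyl together, so which of the two goes with the higher number stays open. Also open, going by these compounds, is whether a 4-aminopiperidin-1-yl or a piperidine bearing a carboxylic acid on that ring carbon would stay level with the bare ring or move away from it.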